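The source may report more compounds than this note shows. Statements on the series, on what has been measured and on what is new or still open speak of the compounds shown alone.

In an ADME assay on Vero cells (Chlorocebus sabaeus) for cytotoxicity, read by MTT assay, with a stated time of 72 h (on this read-out lower numbers stand for an effect already at smaller amounts and higher numbers for an effect only at larger amounts of compound), compound 1 (`COc1ccccc1C(=O)Nc1nc(-c2ccccn2)cs1`) gives 43500 nM, compound 2 (`CC(=O)c1ccccc1C(=O)Nc1nc(-c2ccccn2)cs1`) gives 86700 nM, and compound 3 (`O=C(Nc1nc(-c2ccccn2)cs1)c1ccccc1Br`) gives 3500 nM, the lowest of the three numbers. Compound 4 (`O=C(Nc1nc(-c2ccccn2)cs1)c1cccnc1Cl`) has 2-chloropyridin-3-yl in place of 2-bromophenyl on a carbonyl carbon. Going by the values given here, no measured step makes this exact exchange. The closest evidence is the bromo steps, a 12-fold lower number from compound 1 to compound 3 (1.09 log units; beyond the scatter) and a 25-fold lower number from compound 2 to compound 3 (1.39 log units; beyond the scatter), both large, while a 2.0-fold higher number from compound 1 to compound 2 (0.30 log units; within the scatter) stays within the scatter. With bromo gone, a moderate move towards higher numbers is expected, smaller than those bromo steps, and the size is uncertain. The expected step is a 4.0-fold higher number from compound 3 to compound 4 (0.60 log units; beyond the scatter). Compound 4 is estimated at 14000 nM, with an expected range from 4000 nM to 50000 nM.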

Compound 4, half-maximal effective concentration: 1900 nM
Beside the measured number, compound 4's estimate is 7.4-fold (0.87 log units) above it, outside the stated range (below it).
By their numbers in this assay, from the lowest: compounds 4 and 3 (each within the scatter of the next); then compounds 1 and 2 (each within the scatter of the next).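

In this assay the exchange of 2-bromophenyl for 2-chloropyridin-3-yl on a carbonyl carbon gives a 1.8-fold lower number from compound 3 to compound 4 (0.27 log units; within the scatter), so the two groups cannot be told apart on this read-out. The low numbers at this position are therefore not tied to bromo or to a ring of carbon only, since a ring with a hetero atom and a chlorine stands level with it. No measurement shown gives a reason for this result. As far as these compounds go, because ring and halogen change together, what each contributes alone remains open. So does whether a ring carrying an amine or a carboxylic acid in place of the halogen would keep such numbers.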